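The compounds below may be only part of what the source reports. "The series", "measured", "known", "first", "only" and "open" are said of these compounds alone.

Working notes on the series. Compound 3 `CC1=C(/C=C/C(=O)/C=C/c2cccc([N+](=O)[O-])c2)C(C)(C)CCC1` carries a nitro group on the aromatic ring at the end of the dienone chain. Within the data shown here, in a functional assay on LNCaP cells (Homo sapiens) for cytotoxicity, read by MTT assay, with a stated time of 72 h (on this read-out higher numbers stand for weaker inhibition and lower numbers for stronger inhibition), compound 3 gives 2700 nM, the lowest number among the three measured members. Compound 1 `CC1=C(/C=C/C(=O)/C=C/c2ccccc2F)C(C)(C)CCC1` gives 10700 nM in this assay and compound 2 `CC1=C(/C=C/C(=O)/C=C/c2cccc(F)c2)C(C)(C)CCC1` gives 12900 nM; both of these numbers stand beyond the scatter from that of compound 3. Among the measured compounds shown here, the step of a 1.2-fold higher number from compound 1 to compound 2 (0.08 log units; within the scatter) lies within the scatter, whereas the step of a 4.8-fold lower number from compound 2 to compound 3 (0.68 log units; beyond the scatter) is the one change at the substituent in question.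

Compound 4 `CC1=C(/C=C/C(=O)/C=C/c2cccc(C)c2)C(C)(C)CCC1` differs from compound 3 by methyl in place of nitro on an aromatic carbon. For the measured compounds named here, no measured pair exchanges nitro for methyl directly; the only bearing step is a 4.8-fold lower number from compound 2 to compound 3 (0.68 log units; beyond the scatter), where nitro in place of fluoro lowered the number. Methyl in place of nitro removes that group again, so a move back toward the fluoro level is expected, an expected step of a 3.3-fold higher number from compound 3 to compound 4 (0.52 log units; beyond the scatter). Compound 4 is therefore expected to give 9000 nM in this assay, with a range from 3000 nM to 25000 nM.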

Compound 4, half-maximal inhibitory concentration: 17800 nM
The estimate for compound 4 lay 2.0-fold (0.30 log units) below the measured number, within the range that was stated.
By their numbers in this assay, from the lowest: compound 3; then compounds 1, 2 and 4 (each within the scatter of the next).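

The direct exchange of nitro for methyl on this aromatic carbon gives a 6.6-fold higher number from compound 3 to compound 4 (0.82 log units; beyond the scatter) in this assay, so the low number of compound 3 does not carry over to the methyl group. Compound 4 instead sits with the two fluoro members: a 1.4-fold higher number from compound 2 to compound 4 (0.14 log units; within the scatter) and a 1.7-fold higher number from compound 1 to compound 4 (0.22 log units; within the scatter) both remain within the scatter, so methyl and fluoro are not told apart here. Among the groups shown, nitro alone stands apart at this place, and nothing measured in the series speaks to why.

Going by these compounds, whether a nitrile, an amine or a carboxylic acid on this aromatic carbon would reach the low number of compound 3 stays open. Also open, on these data alone, is whether nitro on another carbon of the aromatic ring would give the same result.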